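Swapping a Thiophene for a Pyridine at the Chain End

The compounds below may be only part of what the source reports. "The series", "measured", "known", "first", "only" and "open" are said of these compounds alone.

Compound 3 `Cc1ccc(CCOc2ccc(-c3c(C)nc(C)c([C@H](OC(C)(C)C)C(=O)O)c3N3CCC(C)(C)CC3)cc2)s1` carries the shared core with a 2-(5-methylthiophen-2-yl)ethyl chain on an oxygen on an aromatic ring. In an ADME assay on microsomes from liver (Homo sapiens) for metabolic stability, read by LC-MS, tested at 0.5 uM (on this read-out lower numbers stand for a shorter-lived compound and higher numbers for a longer-lived compound), compound 3 gives > 2 h, which is a limit of the assay and not a number. Compound 1 `Cc1nc(C)c([C@H](OC(C)(C)C)C(=O)O)c(N2CCC(C)(C)CC2)c1-c1ccc(OCCCc2ccc(F)cc2)cc1` in this assay also gives > 2 h, again a limit. Compound 2 `Cc1nc(C)c([C@H](OC(C)(C)C)C(=O)O)c(N2CCC(C)(C)CC2)c1-c1ccc(OC2COCC2c2ccc(F)cc2)cc1` gives 0.783 h in this assay, the one plain number shown. The step of an at least 2.5-fold higher number from compound 2 to compound 3 (0.40 log units; beyond the scatter) is readable, while the step that the two limits leave unreadable from compound 1 to compound 3 is not, since both ends sit at the limit (the limit of > 2 h in this assay, at which 2 of the 3 values shown sit). Compound 4 `Cc1nc(C)c([C@H](OC(C)(C)C)C(=O)O)c(N2CCC(C)(C)CC2)c1-c1ccc(OCCc2cccnc2)cc1` differs from compound 3 by pyridin-3-yl in place of 5-methylthiophen-2-yl on a saturated chain carbon, two bonds along the chain from an oxygen on an aromatic ring. The closest comparison is the step from compound 1 to compound 3, where a different ring was put in the same place, yet it cannot be read; the step from compound 2 to compound 3 changes the linker as well as the ring and so speaks only loosely to this swap. For the measured compounds named here, no measured step therefore shows how a pyridine ring in this place changes the half-life, and no shift beyond the scatter can be claimed in this assay. Compound 4 is expected to give about 1.5 h, between 0.7 h and 3.5 h. The estimate for compound 4 therefore amounts to an at least 1.3-fold lower number from compound 3 to compound 4 (0.12 log units; that floor lies within the scatter).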

Compound 4, half-life: 0.367 h
Beside the measured number, compound 4's estimate is 4.1-fold (0.61 log units) above it, and the stated range ends above it.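

In this assay, the pyridin-3-yl ring gives the first readable result for a swap on a saturated chain carbon, two bonds along the chain from an oxygen on an aromatic ring: the change is an at least 5.4-fold lower number from compound 3 to compound 4 (0.73 log units; beyond the scatter), and the change is of the same size in an at least 5.4-fold lower number from compound 1 to compound 4 (0.73 log units; beyond the scatter), where pyridin-3-yl replaces 4-fluorobenzyl. Compound 1 and compound 3 could not show on their own that the ring at the chain end matters to the half-life, because both sit at a limit of the assay: the limit of > 2 h in this assay, at which 2 of the 4 values shown sit. For the compounds shown here, the new chain also compares unfavourably with the 4-(4-fluorophenyl)oxolan-3-yl group, the one earlier group with a plain number, as the half-life shows a 2.1-fold lower number from compound 2 to compound 4 (0.33 log units; beyond the scatter).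

As far as these compounds go, both steps that start from a limit give only a floor, so the full size of the drop from compound 1 or compound 3 stays open. From the compounds shown here alone, it also stays open whether the ring nitrogen or its place in the ring decides the outcome, since how a pyridin-4-yl or a plain phenyl ring would behave on this same chain cannot be told from these compounds.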